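The source may report more compounds than this note shows. Statements on the series, on what has been measured and on what is new or still open speak of the compounds shown alone.

Of the compounds shown here, two sharing one core have been measured so far. In a physicochemical assay for lipophilicity, measured as octanol-water partition (on this read-out lower numbers stand for lower lipophilicity and higher numbers for higher lipophilicity), compound 1 `COC(=O)c1ccc(/C=C/C(=O)N[C@@H]2O[C@H](CO)[C@@H](O)[C@H](O)[C@H]2O)cc1` gives -0.805, while compound 2 `CC(C)c1ccc(/C=C/C(=O)N[C@@H]2O[C@H](CO)[C@@H](O)[C@H](O)[C@H]2O)cc1` gives 0.296, the higher of the two numbers. Among the measured compounds shown here, the only measured step is a number 1.10 log units higher from compound 1 to compound 2 (beyond the scatter), which came with isopropyl in place of methoxycarbonyl on an aromatic carbon.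

Compound 3 `O=C(/C=C/c1ccc(-c2ccccc2)cc1)N[C@@H]1O[C@H](CO)[C@@H](O)[C@H](O)[C@H]1O` has yet to be measured. It differs from compound 2 by phenyl in place of isopropyl on an aromatic carbon, para to a large group. The earlier step bears on this only indirectly, as it exchanged a different pair of groups. Here one all-carbon group gives way to a larger all-carbon group, and no measured step covers such a swap. Starting from compound 2 at 0.296, a moderate rise in this assay is expected, smaller than a number 1.10 log units higher from compound 1 to compound 2 (beyond the scatter). The expected change is a number 0.40 log units higher from compound 2 to compound 3 (beyond the scatter), an estimate with wide uncertainty. For compound 3 the estimated value is 0.7, with an expected range from 0.3 to 1.15.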

Compound 3, partition coefficient: 0.851
Beside the measured number, compound 3's estimate is 0.15 log units below it, and the stated range covers the measured number.
By their numbers in this assay, from the lowest: compound 1; then compound 2; then compound 3.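

In this assay, the change from isopropyl to phenyl on an aromatic carbon, para to a large group, gives a number 0.56 log units higher from compound 2 to compound 3 (beyond the scatter) and so shows that this position still responds when one all-carbon group replaces a larger all-carbon group with one six-membered aromatic ring, a kind of exchange the earlier pair did not cover. Measured against methoxycarbonyl, phenyl gives a number 1.66 log units higher from compound 1 to compound 3 (beyond the scatter) and this is the widest separation among the three compounds, whose order at this one position now runs from methoxycarbonyl through isopropyl to phenyl. No supporting information is available to explain the size of either step.

From the compounds shown here alone, whether a longer chain such as hexyl would carry the read-out past phenyl, or whether an amine or a carboxylic acid would bring it under methoxycarbonyl, remains open. Also open, going by these compounds, is whether phenyl owes its place to its ring or simply to its six carbons, and whether the same order of groups would hold on any core other than the shared one.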